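A Fluoropyridine Replaces the Nitrile on the Shared Core

This account rests on a few compounds, and the source may have more. Where it says the series, first, only, none or still open, it means among the compounds named here.

Three compounds have been measured in a functional assay on KB cells (Homo sapiens) for inhibition, with a stated time of 72 h; a lower number here means a stronger inhibitor, a higher number a weaker inhibitor:
Compound 1, `COc1ccc(S(=O)(=O)N2CCc3cccc(-c4ccc([N+](=O)[O-])cc4)c32)cc1`, gives 52.5 nM.
Compound 2, `COc1ccc(S(=O)(=O)N2CCc3cccc(-c4ccc(F)cc4)c32)cc1`, gives 86 nM.
Compound 3, `COc1ccc(S(=O)(=O)N2CCc3cccc(-c4ccc(C#N)cc4)c32)cc1`, gives 31.1 nM.

Compound 3 holds the lowest of the three numbers. Its gap to compound 1 is small: a 1.7-fold lower number from compound 1 to compound 3 (0.23 log units; within the scatter). Its gap to compound 2 is larger: a 2.8-fold lower number from compound 2 to compound 3 (0.44 log units; beyond the scatter). So compound 3 and compound 1 cannot be told apart, while compound 3 does stand apart from compound 2.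

The next compound, compound 4, is `COc1ccc(S(=O)(=O)N2CCc3cccc(-c4ccc(F)nc4)c32)cc1`. It differs from compound 3 in one place: 6-fluoropyridin-3-yl in place of 4-cyanophenyl on an aromatic carbon. Within the data shown here, two measured steps bear on this change. The exchange of fluoro for nitro, a 1.6-fold higher number from compound 1 to compound 2 (0.21 log units; within the scatter), changed little. The exchange of cyano for fluoro, a 2.8-fold lower number from compound 2 to compound 3 (0.44 log units; beyond the scatter), was a modest gain. Among the measured compounds shown here, compound 4 carries a fluoro, as compound 2 does, but it also carries a ring nitrogen that no measured compound has, so the data give no direct guide for that part. The number for compound 4 is therefore expected to move back toward that of compound 2, a modest step: a 2.3-fold higher number from compound 3 to compound 4 (0.35 log units; beyond the scatter). The estimate for compound 4 in this assay is 70 nM, with a likely range from 30 nM to 170 nM.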

Compound 4, half-maximal inhibitory concentration: 143 nM
For compound 4 the middle estimate is 2.0-fold (0.31 log units) below the measured one; measured number inside the range.
By their numbers in this assay, from the lowest: compounds 3, 1, 2 and 4 (each within the scatter of the next, the first and the last beyond it).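

In this assay, among these compounds, the most informative new step keeps the fluoro and changes only the ring: 6-fluoropyridin-3-yl in place of 4-fluorophenyl stays within the scatter (a 1.7-fold higher number from compound 2 to compound 4 (0.22 log units; within the scatter)), so the ring nitrogen, which no earlier compound carried, makes no difference these numbers can detect at this position. The other two steps are modest but lie beyond the scatter, both for 6-fluoropyridin-3-yl in place of 4-cyanophenyl (a 4.6-fold higher number from compound 3 to compound 4 (0.66 log units; beyond the scatter)) and for 6-fluoropyridin-3-yl in place of 4-nitrophenyl (a 2.7-fold higher number from compound 1 to compound 4 (0.44 log units; beyond the scatter)), so compound 4 stands apart from compound 3 and compound 1 while it cannot be told apart from compound 2. Nothing measured here goes beyond these cell numbers, so they describe the differences without accounting for them.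

A pyridine ring carrying a nitrile instead of the fluoro would show whether the nitrile keeps its advantage over the fluoro on that ring, and the compounds shown leave this open. Also open, going by these compounds, is what an amine or a carboxylic acid would give on the same aromatic ring.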